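A few compounds are considered here, and "the series" means these few. Any claim that something is new, unique, unknown or untested is made for them only; others in the source may bear on it.

Compound 1 `O=C(Nc1cccc(-n2cc(-c3ccncc3)c(-c3ccc(Cl)c(O)c3)n2)c1)Nc1cccc(C(F)(F)F)c1`: in a functional assay on COLO 205 cells (Homo sapiens) for inhibition, read by sulforhodamine B assay, with a stated time of 48 h (a lower number here means a stronger inhibitor of growth, a higher number a weaker inhibitor of growth), compound 1 gives 23800 nM.
Compound 2 `COc1cc(-c2nn(-c3cccc(NC(=O)Nc4cc(C(F)(F)F)cc(C(F)(F)F)c4)c3)cc2-c2ccncc2)ccc1Cl`: in this assay compound 2 gives 1570 nM.
Compound 3 `COc1cc(-c2nn(-c3cccc(NC(=O)Nc4cccc(C(F)(F)F)c4)c3)cc2-c2ccncc2)ccc1Cl`: in this assay compound 3 gives 1750 nM.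

Among these three, compound 2 has the lowest number. Compound 3 sits within the scatter of it, so the two cannot be told apart, while compound 1 lies far beyond the scatter with a much higher number.

Compound 4 `O=C(Nc1cccc(-n2cc(-c3ccncc3)c(-c3ccc(Cl)c(O)c3)n2)c1)Nc1cc(C(F)(F)F)cc(C(F)(F)F)c1` is reached from compound 2 by one change: hydrogen in place of methyl on an oxygen on an aromatic ring. The same change, run the other way, is already on record: a 14-fold lower number from compound 1 to compound 3 (1.13 log units; beyond the scatter). Compound 1 and compound 3 carry one trifluoromethyl on the urea aryl, whereas compound 2 and compound 4 carry two; that extra group mattered little, as shown by a 1.1-fold higher number from compound 2 to compound 3 (0.05 log units; within the scatter). The methyl-to-hydrogen step should therefore carry over, and for compound 4 the expected step is a 13-fold higher number from compound 2 to compound 4 (1.13 log units; beyond the scatter), toward a higher number. Compound 4 is estimated at 21000 nM, with a likely range of 7000 nM to 60000 nM.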

Compound 4, concentration for total growth inhibition: 1580 nM
Estimate against measurement, compound 4: 13-fold (1.12 log units) above; the whole stated range lies above it.
By their numbers in this assay, from the lowest: compounds 2, 4 and 3 (each within the scatter of the next); then compound 1.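

The methoxy to hydroxy change has no fixed effect at this position. With two trifluoromethyl groups on the urea aryl, this assay shows a 1.0-fold higher number from compound 2 to compound 4 (0.00 log units; within the scatter), so the large step seen with one trifluoromethyl does not carry over: the same change on two cores in this assay, a 14-fold lower number (1.13 log units; beyond the scatter) from compound 1 to compound 3 and a 1.0-fold lower number (0.00 log units; within the scatter) from compound 4 to compound 2, 14-fold (1.13 log units) apart, beyond the scatter of two such steps. The second trifluoromethyl, which made no measurable difference to the methoxy compounds, counts once the hydroxy is present, with a 15-fold lower number from compound 1 to compound 4 (1.18 log units; beyond the scatter), and the two changes therefore depend on each other: the same change on two cores in this assay, a 1.1-fold higher number (0.05 log units; within the scatter) from compound 2 to compound 3 and a 15-fold higher number (1.18 log units; beyond the scatter) from compound 4 to compound 1, 14-fold (1.13 log units) apart, beyond the scatter of two such steps.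

This rests on just four compounds, and only compound 1 stands apart from the rest, so the numbers do not say why the two groups interact. Also open, from the compounds shown here alone, is what an ethoxy group or an amine in place of the hydroxy would give on each of the two urea aryl patterns.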